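A few compounds are considered here, and "the series" means these few. Any claim that something is new, unique, unknown or untested is made for them only; others in the source may bear on it.

Two analogues on a shared core have been measured in a functional assay on HT-29 cells (Homo sapiens) for cytotoxicity, read by sulforhodamine B assay, with a stated time of 48 h, tested at 100 nM; a higher number here means a weaker effect of the compound at the concentration tested, a lower number a stronger effect. Compound 1, `Cc1cc(O)cc(-c2nn(CC#N)cc2-c2ccnc(-c3ccc(Oc4ccccc4)cc3)c2)c1`, gives in this assay 91%. Compound 2, `COc1cc(C)cc(-c2nn(CC#N)cc2-c2ccnc(-c3ccc(N(C)C)cc3)c2)c1`, gives in this assay 25%, which is the lowest of the two numbers, and the gap to compound 1 lies beyond the scatter. These two compounds differ in more than one place, so their values show only what each compound does on its own.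

The next compound to be measured is compound 3, `Cc1cc(O)cc(-c2nn(CC#N)cc2-c2ccnc(-c3ccc(N(C)C)cc3)c2)c1`. It keeps the dimethylamino-bearing side of compound 2 and changes the other side: hydrogen in place of methyl on an oxygen on an aromatic ring. Among the compounds with values here, no step of this kind between measured compounds is available, and the numbers for compound 1 and compound 2 do not isolate it, so the size of the step is uncertain. A modest rise from compound 2 is expected, with a wide range, since the methyl is the only heavy atom that leaves and no donor or acceptor count changes in a way that the data connect to this assay. The estimate for compound 3 in this assay is 38%, between 12% and 80%. That estimate means a step from compound 2 to compound 3 of a number 13 percentage points higher from compound 2 to compound 3 (beyond the scatter).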

Compound 3, a percentage reported as activity, at one concentration (the size of the read-out at that concentration, not a potency): 102%
Compound 3: the middle estimate sits 64 percentage points below what was measured, and the stated range ends below it.
By their numbers in this assay, from the lowest: compound 2; then compound 1; then compound 3.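

In this assay the change of methoxy to hydroxy, from 3-methoxy-5-methylphenyl to 3-hydroxy-5-methylphenyl, gives a number 77 percentage points higher from compound 2 to compound 3 (beyond the scatter) and so shows that, with dimethylamino held in place, this single methyl on an oxygen on an aromatic ring separates the strongest effect of the three compounds from the weakest. With the hydroxy held in place, dimethylamino in place of phenoxy on an aromatic carbon gives a number 11 percentage points higher from compound 1 to compound 3 (beyond the scatter) and is a much smaller step, so dimethylamino alone does not bring the low number seen for compound 2, which carries it together with the methoxy. Nothing available here accounts for the size of the step on that oxygen.

The compounds shown leave open whether methoxy to hydroxy does the same where phenoxy stands in place of dimethylamino, as the step is known in one setting only. They also leave open whether the methyl itself is what counts, which an ethoxy group, a longer chain on that oxygen or an amine in its place would help to settle.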